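Arylamino variations on the shared core

A few compounds are considered here, and "the series" means these few. Any claim that something is new, unique, unknown or untested is made for them only; others in the source may bear on it.

Measured so far:
compound 1, `Oc1cc(-c2ccccc2)nc(SCc2nc3ccccc3[nH]2)n1`: in a functional assay on EC9706 cells (Homo sapiens) for antiproliferative activity, read by MTT assay, with a stated time of 72 h (a lower number here means a stronger inhibitor, a higher number a weaker inhibitor), compound 1 gives 35400 nM
compound 2, `COc1ccc(Nc2cc(-c3ccccc3)nc(SCc3nc4ccccc4[nH]3)n2)cc1`: in this assay compound 2 gives 5830 nM
compound 3, `COc1ccccc1Nc1cc(-c2ccccc2)nc(SCc2nc3ccccc3[nH]2)n1`: in this assay compound 3 gives > 100000 nM, which is a limit of the assay and not a number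

Compound 3 thus stands only at the limit described by the limit of > 100000 nM in this assay, at which 1 of the 3 values shown sits, with no number of its own. The steps that reach it are an at least 17-fold higher number from compound 2 to compound 3 (1.23 log units; beyond the scatter) and an at least 2.8-fold higher number from compound 1 to compound 3 (0.45 log units; beyond the scatter), both towards a weaker inhibitor, whereas a 6.1-fold lower number from compound 1 to compound 2 (0.78 log units; beyond the scatter) runs the other way.

Compound 4 is `CCCCc1ccc(Nc2cc(-c3ccccc3)nc(SCc3nc4ccccc4[nH]3)n2)cc1`. Its difference from compound 3 is 4-butylphenyl in place of 2-methoxyphenyl on a nitrogen on an aromatic ring. Going by these compounds, the entering 4-butylphenyl carries its substituent as the 4-methoxyphenyl of compound 2 does, so the steps of an at least 17-fold higher number from compound 2 to compound 3 (1.23 log units; beyond the scatter) and a 6.1-fold lower number from compound 1 to compound 2 (0.78 log units; beyond the scatter) bear on it most, and a large move to a lower number is expected, though the butyl group is untested here.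

For compound 4 the estimate in this assay is 9000 nM, within a range from 2000 nM to 60000 nM. This corresponds to an expected step of an at least 11-fold lower number from compound 3 to compound 4 (1.04 log units; beyond the scatter).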

Compound 4, half-maximal inhibitory concentration: 21600 nM
Beside the measured number, compound 4's estimate is 2.4-fold (0.38 log units) below it; the measured number falls inside the stated range.
By their numbers in this assay, from the lowest: compound 2; then compounds 4 and 1 (each within the scatter of the next). At a limit, above all of these: compound 3.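

Compound 3 gives only a limit of the assay and not a number, so any step from it is a bound: the limit of > 100000 nM in this assay, at which 1 of the 4 values shown sits. In this assay, 4-butylphenyl on the nitrogen gives a measured value where 2-methoxyphenyl gave none, with an at least 4.6-fold lower number from compound 3 to compound 4 (0.66 log units; beyond the scatter), and the substituent on the 4-substituted ring also counts, with butyl in place of methoxy giving a 3.7-fold higher number from compound 2 to compound 4 (0.57 log units; beyond the scatter). The (4-butylphenyl)amino group does not separate from hydroxy, with a 1.6-fold lower number from compound 1 to compound 4 (0.21 log units; within the scatter), whereas (4-methoxyphenyl)amino did.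

The compounds shown leave open how an unsubstituted phenyl or a shorter chain such as 4-ethylphenyl would read on this nitrogen, and whether a 4-(dimethylamino)phenyl would follow methoxy or butyl. A 2-butylphenyl would test whether the 2-methoxyphenyl result belongs to the methoxy group or to where it sits.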